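The compounds below may be only part of what the source reports. "The series", "measured", "known", "first", "only" and "open" are said of these compounds alone.

Measured in a functional assay on A549 cells (Homo sapiens) for antiproliferative activity, read by MTT assay, with a stated time of 24 h; a higher number here means a weaker inhibitor, a lower number a stronger inhibitor:
compound 1, `COc1ccc(-c2cc(/C=C/C(=O)c3ccc(C)cc3)nc3cc(-c4ccccc4)nn23)cc1OC`, gives 17200 nM
compound 2, `COc1ccc(-c2cc(/C=C/C(=O)c3ccc(C)c(C)c3)nc3cc(-c4ccccc4)nn23)cc1OC`, gives 9300 nM
compound 3, `COc1cc(-c2cc(/C=C/C(=O)c3ccc(C)cc3)nc3cc(-c4ccccc4)nn23)cc(OC)c1OC`, gives 19400 nM

Within the series of compound 1 and compound 2 the one counted change is hydrogen in place of methyl on an aromatic carbon; the step is a 1.8-fold higher number from compound 2 to compound 1 (0.27 log units; within the scatter). From compound 1 to compound 3 the change is a methoxy in place of hydrogen on an aromatic carbon, and the step is a 1.1-fold higher number from compound 1 to compound 3 (0.05 log units; within the scatter). Between compound 2 and compound 3 the two cores differ in more than one place, and that difference is not broken down here; their numbers stand apart beyond the scatter.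

Compound 4, `COc1cc(-c2cc(/C=C/C(=O)c3ccccc3)nc3cc(-c4ccccc4)nn23)cc(OC)c1OC`, is not yet measured. It differs from compound 3 by hydrogen in place of methyl on an aromatic carbon. Among the measured compounds shown here, this is the same kind of change as the one from compound 2 to compound 1, but not the same: there the leaving methyl sat ortho to a methyl group (1 heavy atom) and meta to a large group, here it sits para to a large group. A step of similar modest size is expected, a 1.5-fold higher number from compound 3 to compound 4 (0.17 log units; within the scatter), resting on a 1.8-fold higher number from compound 2 to compound 1 (0.27 log units; within the scatter). For compound 4 in this assay the expected number is 29000 nM, estimated to fall between 15000 nM and 60000 nM.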

Compound 4, half-maximal inhibitory concentration: 18200 nM
Compound 4: the middle estimate sits 1.6-fold (0.20 log units) above what was measured, and the stated range covers the measured number.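

In this assay, the change of 4-methylphenyl to phenyl on this core gives a 1.1-fold lower number from compound 3 to compound 4 (0.03 log units; within the scatter), so on this core the hydrogen-for-methyl change cannot be told apart from repeat measurement. Set beside the earlier step on the other core, the change gives no sign of depending on the core: the same change on two cores in this assay, a 1.8-fold higher number (0.27 log units; within the scatter) from compound 2 to compound 1 and a 1.1-fold lower number (0.03 log units; within the scatter) from compound 3 to compound 4, 2.0-fold (0.29 log units) apart, within the scatter of two such steps. Among the compounds shown here, this means only that both steps stay small enough to be read as no clear effect; with just two pairs, it does not show that the change carries over unaltered to other cores, nor that the two steps are truly the same.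

Still open, from the compounds shown here alone, is whether a different group at this place, para to a large group, such as an amine, a carboxylic acid or a longer alkyl chain, would move the number beyond the scatter. Also open, going by these compounds, is whether the hydrogen-for-methyl change reads the same way in any read-out other than this assay.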